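Tert-Butyl for Methoxy Carried onto a Second Core

The source may hold more compounds than are shown below. What is called first, only, known or untested is meant among the compounds shown, and "the series" means these compounds.

Compound 1 `COc1ccc(NC(=O)Nc2cccc(CNc3ncnc4ccccc34)c2)cc1` and compound 2 `CC(C)(C)c1ccc(NC(=O)Nc2cccc(CNc3ncnc4ccccc34)c2)cc1` share one core. In a functional assay on A549 cells (Homo sapiens) for antiproliferative activity, read by MTT assay (on this read-out lower numbers stand for stronger inhibition and higher numbers for weaker inhibition), compound 1 gives 29300 nM, and compound 2 gives 17900 nM. The change between them, (tert-butyl in place of methoxy on an aromatic carbon), made a 1.6-fold lower number from compound 1 to compound 2 (0.21 log units; within the scatter). Compound 3 `COc1ccc(NC(=O)Nc2cccc(CNc3ncnc4cc(OC)c(OC)cc34)c2)cc1` rests on a second core; the difference between the two cores is not broken down here. In this assay compound 3 gives 24500 nM, close to compound 1. Compound 4 `COc1cc2ncnc(NCc3cccc(NC(=O)Nc4ccc(C(C)(C)C)cc4)c3)c2cc1OC` applies the same change to the core of compound 3: tert-butyl in place of methoxy on an aromatic carbon, at a place described in the same words as before. Because the earlier change made a 1.6-fold lower number from compound 1 to compound 2 (0.21 log units; within the scatter), a step of about the same size is expected, namely a 1.6-fold lower number from compound 3 to compound 4 (0.21 log units; within the scatter) in this assay. Compound 4 is therefore estimated at 15000 nM in this assay, likely between 7000 nM and 35000 nM.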

Compound 4, half-maximal inhibitory concentration: 5210 nM
Beside the measured number, compound 4's estimate is 2.9-fold (0.46 log units) above it; the whole stated range lies above it.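

Tert-butyl in place of methoxy made a 4.7-fold lower number from compound 3 to compound 4 (0.67 log units; beyond the scatter) in this assay. The size of the step did not carry over unchanged from one core to the other: the same change on two cores in this assay, a 1.6-fold lower number (0.21 log units; within the scatter) from compound 1 to compound 2 and a 4.7-fold lower number (0.67 log units; beyond the scatter) from compound 3 to compound 4, 2.9-fold (0.46 log units) apart, beyond the scatter of two such steps This rests on one pair of compounds per core, so it shows that the two cores responded differently here, but it does not show why, or how the change would behave on any further core.

The compounds shown leave open whether other groups at that place, such as an amine, a carboxylic acid or a longer alkyl chain, would also give steps that differ between the two cores. They also leave open which part of the difference between the cores goes with the larger step.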